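A few compounds are considered here, and "the series" means these few. Any claim that something is new, unique, unknown or untested is made for them only; others in the source may bear on it.

Compound 1, `CC(C)Nc1nccc(-c2cn[nH]c2)n1`, is the starting point of this comparison. In an in vitro ADME assay on microsomes from liver (Homo sapiens) for metabolic stability (a higher number here means faster removal of the compound, a lower number slower removal), compound 1 gives 0.021 mL/min/kg. Two other compounds share its core. Compound 2, `OC1CCCC(c2n[nH]cc2-c2ccnc(NC3CCCC3)n2)C1`, gives 0.015 mL/min/kg in this assay, and compound 3, `CC(C)Nc1nccc(-c2c[nH]nc2C2CCN(S(C)(=O)=O)CC2)n1`, gives 0.012 mL/min/kg. The gap from compound 1 to each of the other two lies within the scatter of repeated measurements, so on these numbers the three compounds cannot be told apart.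

Compound 4, `CC(C)Nc1nccc(-c2c[nH]nc2C2CCCOC2)n1`, has not yet been measured in this assay. It differs from compound 1 in one place: oxan-3-yl in place of hydrogen on an aromatic carbon.

For the measured compounds named here, no measured pair in this set isolates this particular change. Compound 2 and compound 3, which each carry a large group at the same position of the five-membered ring, give numbers close to that of compound 1, so the step from compound 1 to compound 4 is expected to be a 1.3-fold lower number from compound 1 to compound 4 (0.12 log units; within the scatter), with no change beyond the scatter in either direction. Compound 4 is therefore estimated to give 0.016 mL/min/kg in this assay, within a range from 0.008 mL/min/kg to 0.032 mL/min/kg.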

Compound 4, clearance: 0.034 mL/min/kg
Compound 4: the middle estimate sits 2.1-fold (0.33 log units) below what was measured; the whole stated range lies below it.
By their numbers in this assay, from the lowest: compounds 3, 2, 1 and 4 (each within the scatter of the next, the first and the last beyond it).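

Placing oxan-3-yl in place of hydrogen on this aromatic carbon gives a 1.6-fold higher number from compound 1 to compound 4 (0.21 log units; within the scatter) in this assay. For the compounds shown here, this is the first direct reading of this change at this position, and it shows that a six-membered non-aromatic ring with one oxygen can replace hydrogen here without a change in clearance that can be told apart from repeat-to-repeat variation. No measurement on hand bears on why the number stays within the scatter.

Still open, as far as these compounds go, is whether a plain cyclohexyl group on the same carbon would give a similar reading, which would show whether the ring oxygen matters. From the compounds shown here alone, it is also open whether an amine or a carboxylic acid attached at this carbon would stay within the scatter of compound 1.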